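An Amide Gives Way to a Urea on the Shared Core

The source may report more compounds than this note shows. Statements on the series, on what has been measured and on what is new or still open speak of the compounds shown alone.

Compound 1 `COc1cc(-c2nn(-c3cccc(NC(=O)Nc4cc(C(F)(F)F)cc(C(F)(F)F)c4)c3)cc2-c2ccncc2)ccc1Cl` and compound 2 `COc1cc(-c2nn(-c3cccc(NC(=O)c4cccc(C(F)(F)F)c4)c3)cc2-c2ccncc2)ccc1Cl` share the same core and differ in the linker and in the outer ring. In a functional assay on A549 cells (Homo sapiens) for inhibition, read by sulforhodamine B assay, with a stated time of 48 h (a higher number here means a weaker inhibitor of growth, a lower number a stronger inhibitor of growth), compound 1 gives 2130 nM. Compound 2 in this assay reaches only the limit of > 50000 nM, and no number is known for it. Compound 2 therefore stands at the weak end of what has been measured, since the limit of > 50000 nM in this assay, at which 1 of the 2 values shown sits, is where its value sits. Compound 3 `COc1cc(-c2nn(-c3cccc(NC(=O)Nc4ccc(Cl)c(Cl)c4)c3)cc2-c2ccncc2)ccc1Cl` has not yet been measured. It differs from compound 2 by (3,4-dichlorophenyl)amino in place of 3-(trifluoromethyl)phenyl on a carbonyl carbon, so that the (3-(trifluoromethyl)phenyl)carbonyl becomes a (3,4-dichlorophenyl)carbamoyl. Within the data shown here, no step between measured compounds is available, so the size of the change must be read from compound 1, which carries a carbamoyl of this kind and is measured at 2130 nM. The step of an at least 16-fold lower number from compound 2 to compound 3 (1.22 log units; beyond the scatter) is therefore expected to be a gain in growth inhibition well beyond the scatter. Compound 3 is expected to give about 3000 nM, between 800 nM and 15000 nM.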

Compound 3, concentration for total growth inhibition: > 50000 nM
Compound 3: no number, only a limit; the forecaster's own chance of this, stated with the estimate: 15%; middle value at least 16-fold (1.22 log units) away from the limit.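

Compound 3, like compound 2, reaches only a limit in this assay, and no step between the two can be read from it: the limit of > 50000 nM in this assay, at which 2 of the 3 values shown sit.

The compounds shown leave open where the actual values of compound 2 and compound 3 lie, and whether (3,4-dichlorophenyl)amino in place of 3-(trifluoromethyl)phenyl on a carbonyl carbon changes growth inhibition at all.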